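The source may hold more compounds than are shown below. What is called first, only, known or untested is meant among the compounds shown, and "the series" means these compounds.

Compound 2 `COc1cc(/C=C/C(=O)Nc2ccccc2)ccc1OCCCCCCCCCCN1CCCCC1` gives 1.83 in a physicochemical assay for lipophilicity, using the shake flask method, measured as octanol-water partition, at pH 7.4 (on this read-out lower numbers stand for lower lipophilicity and higher numbers for higher lipophilicity), the higher of the two numbers in hand; compound 1 `COc1cc(/C=C/C(=O)Nc2ccccc2)ccc1OCCCCCN1CCCCC1` gives 1.65, and the step of a number 0.18 log units higher from compound 1 to compound 2 (within the scatter) stays within the scatter. Compound 3 `COc1cc(/C=C/C(=O)Nc2ccccc2)ccc1OCCCCCCCCCCN1CCCC1` differs from compound 2 by pyrrolidin-1-yl in place of piperidin-1-yl on a saturated chain carbon, ten or more bonds along the chain from an oxygen on an aromatic ring. Going by the values given here, no measured step involves a ring change of this kind; the only step on record, from compound 1 to compound 2, concerns chain length and so gives no direct guide. A small step downward, if any, is expected, as a number 0.28 log units lower from compound 2 to compound 3 (within the scatter). For compound 3 the estimate is 1.55, with a range from 1.2 to 1.9.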

Compound 3, partition coefficient: 1.86
For compound 3 the middle estimate is 0.31 log units below the measured one, within the range that was stated.
By their numbers in this assay, from the lowest: compounds 1, 2 and 3 (each within the scatter of the next).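

In this assay, going by these compounds alone, the first ring change at this position, pyrrolidin-1-yl in place of piperidin-1-yl, reads as a number 0.03 log units higher from compound 2 to compound 3 (within the scatter) and so does not separate the two compounds. The step that alters both chain and ring, a number 0.21 log units higher from compound 1 to compound 3 (within the scatter), does not separate them either. No measurement at hand offers an explanation for these readings.

On these data alone, whether the ring change reads the same on the shorter chain of compound 1 stays open. So does the reading of a morpholine ring, a dimethylamino group or a longer chain at this place.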